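Aryl Fluorides All at the Limit, and a Fourth Awaited

The compounds below may be only part of what the source reports. "The series", "measured", "known", "first", "only" and "open" are said of these compounds alone.

Three compounds were examined in an ADME assay on BJ cells (Homo sapiens) for cytotoxicity, with a stated time of 72 h; a higher number here means that more compound is needed for the effect, a lower number that less compound is needed. Compound 1 `Cc1cc(NC(=O)Nc2ccc(F)c(F)c2)c2ccccc2n1`, compound 2 `Cc1cc(NC(=O)Nc2ccc(F)cc2)c2ccccc2n1` and compound 3 `Cc1cc(NC(=O)Nc2ccccc2F)c2ccccc2n1` share one core and differ only in where fluoro sits. In this assay compound 1 returns only a limit, > 25000 nM, not a number. Compound 2 likewise reports a limit, > 25000 nM. Compound 3 too stops at a limit, > 25000 nM. Hence the steps a step that the two limits leave unreadable from compound 2 to compound 1 and a step that the two limits leave unreadable from compound 2 to compound 3 cannot be sized; the first rests on (fluoro in place of hydrogen on an aromatic carbon), the second on the rearrangement (2-fluorophenyl in place of 4-fluorophenyl on an amide-type nitrogen), and all three values stand on one line, (the limit of > 25000 nM in this assay, at which 3 of the 3 values shown sit).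

Compound 4 `Cc1cc(NC(=O)Nc2cc(F)ccc2F)c2ccccc2n1` is not yet measured. It arises from compound 3 by fluoro in place of hydrogen on an aromatic carbon, the same kind of change as that from compound 2 to compound 1, occurring twice in this set; in compound 1 the entering fluoro stands ortho to a fluoro group, whereas in compound 4 it stands para to a fluoro group. With the earlier step unreadable, the expectation for compound 4 rests on the shared limit (the limit of > 25000 nM in this assay, at which 3 of the 3 values shown sit). Compound 4 is therefore expected to remain at that limit, a step that the limit leaves unreadable from compound 3 to compound 4. The estimate for compound 4 is 35000 nM, lying between 15000 nM and 120000 nM.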

Compound 4, half-maximal effective concentration in the BJ assay: 7000 nM
The estimate for compound 4 lay 5.0-fold (0.70 log units) above the measured number, outside the stated range (below it).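

In the BJ assay, fluoro in place of hydrogen on an aromatic carbon gives an at least 3.5-fold lower number from compound 3 to compound 4 (0.55 log units; beyond the scatter), with the entering fluoro para to a fluoro group and meta to a large group. Compound 1, which carries the same kind of change, gives > 25000 nM, a limit and not a number, so its step and the other steps at the limit cannot be read, and the series shows neither that the change carries from one core to another nor that it fails to. In a physicochemical assay for solubility, at pH 7.4 (a higher number here means a more soluble compound, a lower number a less soluble compound), compound 3 gives 3800 nM and compound 4 gives 500 nM. In the physicochemical assay the change is likewise seen on a single pair, which shows its size there and nowhere else: the measured solubility of compound 3, 3800 nM, and of compound 4, 500 nM, a 7.6-fold lower number (0.88 log units; beyond the scatter)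

On these data alone, compound 4 alone stands off the shared limit, so one readable step gives no general rule for this change: the limit of > 25000 nM in the BJ assay, at which 3 of the 4 values shown sit. Still open is whether a chloro group, a methoxy group or an amine on the same aromatic carbon would give a step of similar size in the BJ assay.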